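Fluoro for chloro on a dihydropyrimidine thioether series

The compounds below may be only part of what the source reports. "The series", "measured", "known", "first", "only" and "open" are said of these compounds alone.

Measured compounds:
compound 1 `COc1ccc(C2N=C(SCc3ccc(Cl)cc3)NC(C)=C2C(=O)Nc2ccc(F)cc2)cc1OC` gives 5.7%
compound 2 `COc1ccc(C2N=C(SCc3ccc(F)cc3)NC(C)=C2C(=O)Nc2ccc(F)cc2)cc1OC` gives 6.7%
compound 3 `COc1ccc(C2N=C(SCc3ccc(Cl)cc3)NC(C)=C2C(=O)Nc2ccc(Br)cc2)cc1` gives 7.2%

All three were tested in a functional assay on the whole organism (artery, strain albino) with Rattus norvegicus as the target, with a stated time of 30 min, at a dose of 10 mg/kg by the oral route; on this read-out higher numbers stand for more inhibition at the one dose given (going by the name of the read-out) and lower numbers for less inhibition. Compound 1 and compound 2 share one core and differ by fluoro in place of chloro on an aromatic carbon; that change made a step of a number 1 percentage points higher from compound 1 to compound 2 (within the scatter). Compound 3 carries a different core; the difference between the two cores is not broken down here. Compound 3 stands at 7.2%, and its values and those of compound 1 and compound 2 lie within the scatter of one another, so no order among them can be read.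

Compound 4 `COc1ccc(C2N=C(SCc3ccc(F)cc3)NC(C)=C2C(=O)Nc2ccc(Br)cc2)cc1` is not yet measured. It differs from compound 3 by fluoro in place of chloro on an aromatic carbon, the same change as from compound 1 to compound 2, at the same place. Within the data shown here, since that earlier step was a number 1 percentage points higher from compound 1 to compound 2 (within the scatter), the expected step in this assay from compound 3 to compound 4 is estimated as a number 0.8 percentage points higher from compound 3 to compound 4 (within the scatter), resting on the one measured pair and on the value of compound 3, 7.2%. Compound 4 is therefore estimated at 8%, expected to fall between 0% and 18%.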

Compound 4, a percentage reported as inhibition, in the whole organism at one dose (the size of the read-out at that dose, not a potency): 6.2%
The estimate for compound 4 lay 1.8 percentage points above the measured number; the measured number falls inside the stated range.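

In this assay, fluoro in place of chloro on the 4-chlorobenzyl group gave a step of a number 1 percentage points lower from compound 3 to compound 4 (within the scatter). Set beside the same change on the other core, this step does not differ from the earlier one: the same change on two cores in this assay, a number 1 percentage points higher (within the scatter) from compound 1 to compound 2 and a number 1 percentage points lower (within the scatter) from compound 3 to compound 4, 2 percentage points apart, within the scatter of two such steps. This shows that on both cores the change left the inhibition at this one dose within the scatter, so the two cores give no sign of treating it differently, but it does not show that the change would carry over with a real effect, since neither step is large enough to be read as one.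

The compounds shown leave open whether an amine or a carboxylic acid in place of the halogen, or a longer chain in place of the benzyl group, would move the number beyond the scatter. They also leave open whether any of these compounds differ from one another at other doses or times.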